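The source may report more compounds than this note shows. Statements on the series, on what has been measured and on what is new or still open speak of the compounds shown alone.

Working notes on a series of three measured compounds and one still open. In a functional assay on UACC-257 cells (Homo sapiens) for cytotoxicity, read by sulforhodamine B assay, with a stated time of 48 h, tested at 10 uM (a lower number here means a stronger effect, a higher number a weaker effect of the compound at the concentration tested), compound 1 `COc1ccc(-c2cc(/C=C/C(=O)c3ccc(OC)c(OC)c3)[nH]n2)cc1` gives -67%, compound 3 `COc1ccc(-c2cc(/C=C/C(=O)c3ccc(N)cc3)[nH]n2)cc1` gives -54% and compound 2 `COc1cc(-c2cc(/C=C/C(=O)c3ccc(Cl)c(Cl)c3)[nH]n2)cc(OC)c1OC` gives 66%. Compound 2 therefore stands highest of the three numbers in this assay, with compound 3 the nearest to it and compound 1 the furthest, both gaps beyond the scatter; on these numbers compound 2 is the weakest of the three. Going by the values given here, no pair among the measured compounds differs in only one place, so no single step is available.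

Compound 4 `COc1ccc(C(=O)/C=C/c2cc(-c3cc(OC)c(OC)c(OC)c3)n[nH]2)cc1OC` is not yet measured in this assay. Against compound 2 the change is 3,4-dimethoxyphenyl in place of 3,4-dichlorophenyl on a carbonyl carbon. Compound 1 carries the same 3,4-dimethoxyphenyl on the carbonyl carbon and gives -67% in this assay, so a step downward, well beyond the scatter, is expected from compound 2 to compound 4, a number 86 percentage points lower from compound 2 to compound 4 (beyond the scatter). Compound 4 is estimated at -20% in this assay, within a range from -70% to 40%.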

Compound 4, a percentage reported as activity, at one concentration (the size of the read-out at that concentration, not a potency): -98%
Beside the measured number, compound 4's estimate is 78 percentage points above it; the measured number lies below the stated range.
By their numbers in this assay, from the lowest: compound 4; then compound 1; then compound 3; then compound 2.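

In this assay, going by these compounds alone, 3,4-dimethoxyphenyl in place of 3,4-dichlorophenyl on a carbonyl carbon gives a number 164 percentage points lower from compound 2 to compound 4 (beyond the scatter), the first comparison in which only one place changes. With everything else in compound 2 held constant, the group on the carbonyl carbon alone is enough to turn the read-out from the highest number in the series to the lowest, so this position strongly controls the outcome at the concentration tested. Nothing available here explains why this exchange has so large an effect.

The compounds shown leave open whether both methoxy groups are needed, since the two ring substituents change together in this step. Also open, going by these compounds, is how a plain phenyl, a 3,4-dihydroxyphenyl or a 3,4-difluorophenyl group would read at this place on the core of compound 4.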